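This account rests on a few compounds, and the source may have more. Where it says the series, first, only, none or still open, it means among the compounds named here.

Working notes on the series.

Two cores are represented. Compound 1 `O=c1cc(-n2cc(CSc3ccccc3)nn2)c2cc(Br)ccc2o1` and compound 2 `O=c1cc(-n2cc(COc3ccccc3)nn2)c2cc(Br)ccc2o1` share the first; compound 3 `O=[N+]([O-])c1cnc2ccc(Br)cc2c1-n1cc(CSc2ccccc2)nn1` and the unmeasured compound 4 `O=[N+]([O-])c1cnc2ccc(Br)cc2c1-n1cc(COc2ccccc2)nn1` share the second. The difference between the two cores is not broken down here.

In a functional assay on MCF7 cells (Homo sapiens) for antiproliferative activity, read by MTT assay, with a stated time of 48 h (on this read-out higher numbers stand for weaker inhibition and lower numbers for stronger inhibition), compound 1 gives 36800 nM. In this assay compound 2 gives 1720 nM. The change between these two is phenoxy in place of phenylsulfanyl on a saturated chain carbon bound to an aromatic carbon, and it made a 21-fold lower number from compound 1 to compound 2 (1.33 log units; beyond the scatter).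

In this assay compound 3 gives 22700 nM. Set against compound 1 this lies within the scatter; set against compound 2 it lies beyond it.

Compound 4 carries the same change on the second core: phenoxy in place of phenylsulfanyl on a saturated chain carbon bound to an aromatic carbon. The place of the change is described in the same words for both pairs, so this is the same change, now made on the core of compound 3 rather than the core of compound 1.

The step from compound 3 to compound 4 in this assay is estimated as a 13-fold lower number from compound 3 to compound 4 (1.10 log units; beyond the scatter), resting on a 21-fold lower number from compound 1 to compound 2 (1.33 log units; beyond the scatter). For the measured compounds named here, only one earlier instance of the change is available, and whether it carries over onto the second core is untested, so the estimate is held a little short of that step and given a wide range. Compound 4 is expected to give about 1800 nM in this assay, between 500 nM and 7000 nM.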

Compound 4, half-maximal inhibitory concentration: 7690 nM
Beside the measured number, compound 4's estimate is 4.3-fold (0.63 log units) below it, outside the stated range (above it).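

In this assay, phenoxy in place of phenylsulfanyl on the core of compound 3 gives a 3.0-fold lower number from compound 3 to compound 4 (0.47 log units; beyond the scatter), so the direction of the change seen on the core of compound 1 holds on the second core. Its size does not carry over, and a step read on one core cannot be moved unchanged to the other: the same change on two cores in this assay, a 21-fold lower number (1.33 log units; beyond the scatter) from compound 1 to compound 2 and a 3.0-fold lower number (0.47 log units; beyond the scatter) from compound 3 to compound 4, 7.2-fold (0.86 log units) apart, beyond the scatter of two such steps

With one pair on each core, this shows only that the direction agrees in these two cases and the size depends on the core in this pair of pairs; it gives no general rule for the series, and nothing here says what in the cores sets the gap between the steps.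

Still open, on these data alone, is whether phenylamino, with an amine in the place of the oxygen or sulfur, would follow the same direction on either core, and how large that step would be. As far as these compounds go, a longer chain between the triazole and the phenyl ring is equally open, as is whether the gap between the two steps would persist on a third core.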